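Ethoxy to Nitro: Expecting Compound 3 in the Cell Assay

The source may hold more compounds than are shown below. What is called first, only, known or untested is meant among the compounds shown, and "the series" means these compounds.

Compound 2, `CCOc1ccc(-n2nncc2CN2C(=O)C3(C(C#N)=C(N)Oc4c3c3nc5ccccc5nc3c3ccccc43)c3ccccc32)cc1`, gives in a functional assay on MCF7 cells (Homo sapiens) for antiproliferative activity, read by MTT assay, with a stated time of 48 h (a lower number here means a stronger inhibitor, a higher number a weaker inhibitor), only a limit, > 50000 nM, so its true position is not pinned down. Compound 1, `N#CC1=C(N)Oc2c(c3nc4ccccc4nc3c3ccccc23)C12C(=O)N(Cc1cnnn1-c1ccc(Br)cc1)c1ccccc12`, gives 36600 nM in this assay. The change from compound 1 to compound 2 is ethoxy in place of bromo on an aromatic carbon, and the measured step was an at least 1.3-fold higher number from compound 1 to compound 2 (0.13 log units; that floor lies within the scatter). Compound 3, `N#CC1=C(N)Oc2c(c3nc4ccccc4nc3c3ccccc23)C12C(=O)N(Cc1cnnn1-c1ccc([N+](=O)[O-])cc1)c1ccccc12`, differs from compound 2 by nitro in place of ethoxy on an aromatic carbon. For the measured compounds named here, only that one measured step bears on this change, and it ran into (the limit of > 50000 nM in this assay, at which 1 of the 2 values shown sits), so it sets a floor rather than a size. Nothing on the numbers shown separates these substituents beyond the scatter, so no step beyond the scatter is expected from compound 2 to compound 3, and the estimated step is a number no higher from compound 2 to compound 3 (the limit leaves the size open). Compound 3 is expected at 50000 nM, within 20000 nM to 120000 nM.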

Compound 3, half-maximal inhibitory concentration: > 50000 nM
Compound 3 gave a limit, no number (the forecaster's own chance of this, stated with the estimate: 50%); the middle value sits exactly at the limit.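

Compound 3 joins compound 2 at a limit, not a number, so a 4-nitrophenyl and a 4-ethoxyphenyl give the same kind of result at this position, and this is now the most common outcome among the compounds shown: the limit of > 50000 nM in this assay, at which 2 of the 3 values shown sit. The step between these two limits cannot be read, so the new result says nothing about which of the two groups does better. Against bromo, the only group here with a true number, the step is an at least 1.3-fold higher number from compound 1 to compound 3 (0.13 log units; that floor lies within the scatter), so the nitro group cannot be told apart from bromo on these data.

As far as these compounds go, it remains open how far past the limit compound 2 and compound 3 truly lie. From the compounds shown here alone, it is also open whether another group on this ring, such as an amine or a carboxylic acid, would give a number clearly lower than that of compound 1.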